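The source may report more compounds than this note shows. Statements on the series, on what has been measured and on what is new or still open speak of the compounds shown alone.

Compounds measured in a functional assay on NCI-H460 cells (Homo sapiens) for antiproliferative activity, read by MTT assay, with a stated time of 48 h; a higher number here means a weaker inhibitor, a lower number a stronger inhibitor:
Compound 1 `COc1cccc(-c2nc3cccc(-c4cc(OC)c(OC)c(OC)c4)c3o2)c1` gives > 25000 nM, which is a limit of the assay and not a number.
Compound 2 `COc1cc(-c2cccc3nc(-c4ccc(Br)cc4)oc23)cc(OC)c1OC` gives > 25000 nM, likewise a limit and not a number.
Compound 3 `COc1cc(-c2nc3cccc(-c4cc(OC)c(OC)c(OC)c4)c3o2)ccc1O` gives 2000 nM.

Compound 1 thus stands at the limit of > 25000 nM in this assay, at which 2 of the 3 values shown sit. Whether compound 1 and compound 2 differ in this assay cannot be read: a step that the two limits leave unreadable from compound 1 to compound 2. Among the measured compounds shown here, the only readable steps run to compound 3, an at least 12-fold lower number from compound 1 to compound 3 (1.09 log units; beyond the scatter) and an at least 12-fold lower number from compound 2 to compound 3 (1.09 log units; beyond the scatter). Both end at the compound that carries the 4-hydroxy-3-methoxyphenyl group; neither step is accompanied by a measured value that would tell what brings it about.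

Compound 4 `COc1cc(-c2cccc3nc(-c4ccco4)oc23)cc(OC)c1OC` differs from compound 1 thus: furan-2-yl in place of 3-methoxyphenyl on an aromatic carbon. For the measured compounds named here, no measured step shows what an exchange at this position does, since the only step at that place, a step that the two limits leave unreadable from compound 1 to compound 2, is unreadable between two limits. Compound 4 lacks the hydroxy that is present in compound 3. The expectation is therefore that compound 4 remains at the limit, with a step that the limit leaves unreadable from compound 1 to compound 4 expected to be nothing beyond the scatter. The estimate for compound 4 is 30000 nM with a range of 8000 nM to 100000 nM, most likely reported only as a limit.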

Compound 4, half-maximal inhibitory concentration: 2600 nM
For compound 4 the middle estimate is 12-fold (1.06 log units) above the measured one; measured number below the stated range.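

In this assay, the group on the aromatic carbon next to the ring nitrogen and next to the ring oxygen can carry readable activity without a hydroxy: furan-2-yl in place of 3-methoxyphenyl gives an at least 9.6-fold lower number from compound 1 to compound 4 (0.98 log units; beyond the scatter), and furan-2-yl in place of 4-bromophenyl gives an at least 9.6-fold lower number from compound 2 to compound 4 (0.98 log units; beyond the scatter). A hydroxy is therefore no condition for a readable value in this series: furan-2-yl carries none, and its comparison with 4-hydroxy-3-methoxyphenyl gives a 1.3-fold higher number from compound 3 to compound 4 (0.11 log units; within the scatter). Compound 1 and compound 2 each remain at a limit, so among the groups shown at this position, the two six-membered aromatic rings without a hydroxy stay unresolved: the limit of > 25000 nM in this assay, at which 2 of the 4 values shown sit.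

Which feature of furan-2-yl accounts for these steps stays open, as its five-membered ring, its 5 heavy atoms and its ring oxygen all enter together, and the steps between limits cannot be read. Thiophen-2-yl, with sulfur in place of the ring oxygen, or 3-hydroxyphenyl at the same position would help to separate these features and to show whether the furan-2-yl and hydroxy routes are related.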